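Removing a bromo from compound 3: what to expect

The source may hold more compounds than are shown below. What is called first, only, known or untested is meant among the compounds shown, and "the series" means these compounds.

Measured so far in a functional assay on MCF7 cells (Homo sapiens) for antiproliferative activity, read by MTT assay, with a stated time of 24 h (a higher number here means a weaker inhibitor, a lower number a stronger inhibitor), with these results:
- Compound 1 `COC(=O)c1scc(-c2ccc(NC(=O)c3cccc(C(F)(F)F)c3)cc2)c1OC` gives 26200 nM
- Compound 2 `COC(=O)c1scc(-c2ccc(NC(=O)c3ccc(F)c(Cl)n3)cc2)c1OC` gives 10300 nM
- Compound 3 `COC(=O)c1scc(-c2ccc(NC(=O)c3ccc(C(F)(F)F)cc3Br)cc2)c1OC` gives 22400 nM

Compound 3 stands with compound 1 at the high end of these numbers, and the two lie within the scatter of each other. Compound 2 has the lower number, and its gap to compound 3 is beyond the scatter.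

The next compound is compound 4 `COC(=O)c1scc(-c2ccc(NC(=O)c3ccc(C(F)(F)F)cc3)cc2)c1OC` which carries hydrogen in place of bromo on an aromatic carbon. Among the measured compounds shown here, no measured pair shows this exact change. For the measured compounds named here, the one measured step is a 2.5-fold lower number from compound 1 to compound 2 (0.41 log units; beyond the scatter) and it bears only loosely, since it exchanged a whole group, 6-chloro-5-fluoropyridin-2-yl in place of 3-(trifluoromethyl)phenyl on a carbonyl carbon. That larger exchange gave only a modest step, so a much smaller edit is expected to give no step beyond the scatter in this assay and no direction can be called from these data. The estimated step is a 1.0-fold lower number from compound 3 to compound 4 (0.01 log units; within the scatter) and it is expected to stay within the scatter. Compound 4 is expected to read about 22000 nM with an estimated range from 11000 nM to 42000 nM in this measurement.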

Compound 4, half-maximal inhibitory concentration: 24600 nM
Beside the measured number, compound 4's estimate is 1.1-fold (0.05 log units) below it; the range from low to high includes it.
By their numbers in this assay, from the lowest: compound 2; then compounds 3, 4 and 1 (each within the scatter of the next).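

Removing the bromo from the aromatic carbon ortho to a large group gives a 1.1-fold higher number from compound 3 to compound 4 (0.04 log units; within the scatter) in this assay and so leaves the reading within the scatter, which means that bromo and hydrogen at this place cannot be told apart here. Compound 4 also shows that the place of the trifluoromethyl group on the ring does not separate these compounds, since 4-(trifluoromethyl)phenyl in place of 3-(trifluoromethyl)phenyl gives a 1.1-fold lower number from compound 1 to compound 4 (0.03 log units; within the scatter) and stays within the scatter as well. Among these steps, the one beyond the scatter is the exchange of the whole group, with a 2.4-fold higher number from compound 2 to compound 4 (0.38 log units; beyond the scatter) when 4-(trifluoromethyl)phenyl replaces 6-chloro-5-fluoropyridin-2-yl, so the modest gap of compound 2 from compound 4 goes with that larger exchange rather than with the small edits.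

Among the compounds shown here, still open is whether an amine or a carboxylic acid on this same aromatic carbon would move the number beyond the scatter, since bromo and hydrogen are the only two groups compared at this place. No measurement shown here offers a reason for any of these readings.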